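From Methoxy to tert-Butyl on a Serotonin Receptor Ligand

The compounds below may be only part of what the source reports. "The series", "measured", "known", "first", "only" and "open" are said of these compounds alone.

Measured so far:
compound 1 `COc1ccc(OCCNc2cc(N3CCN(C)CC3)ccc2[N+](=O)[O-])cc1`: 245 nM
compound 2 `COc1ccc(N2CCN(C)CC2)cc1NCc1ccccc1`: 409 nM

In an assay on HEK293 cells for displacement of a labelled ligand from 5-hydroxytryptamine receptor 6 (Homo sapiens) (on this read-out higher numbers stand for weaker inhibition and lower numbers for stronger inhibition), compound 1 gives 245 nM and compound 2 gives 409 nM; the two numbers lie within the usual scatter of each other, so neither stands apart from the other. Compound 3 `CN1CCN(c2ccc([N+](=O)[O-])c(NCCOc3ccc(C(C)(C)C)cc3)c2)CC1` differs from compound 1 in a single place: tert-butyl in place of methoxy on an aromatic carbon. Within the data shown here, no measured pair shows what this change does in this assay, so the expectation rests on compound 1 alone. The expected step is a 1.0-fold higher number from compound 1 to compound 3 (0.01 log units; within the scatter), not clearly beyond the scatter in either direction. Compound 3 is estimated at 250 nM, with a range from 80 nM to 800 nM.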

Compound 3, inhibition constant: 80 nM
Beside the measured number, compound 3's estimate is 3.1-fold (0.49 log units) above it; measured number inside the range.
By their numbers in this assay, from the lowest: compound 3; then compounds 1 and 2 (each within the scatter of the next).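

In this assay, among these compounds, putting tert-butyl in place of methoxy gives a 3.1-fold lower number from compound 1 to compound 3 (0.49 log units; beyond the scatter) and this modest step is the first difference here that clears the usual scatter. This position on the ring therefore accepts a group of 4 heavy atoms with no hydrogen-bond acceptor, and inhibition gets stronger rather than being lost. Nothing available explains why the number falls. One pair cannot tell whether the added carbons or the lost oxygen matters more. An isopropyl group, a chlorine atom or an amine at this position could help separate the two.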